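Phenyl to Thiophen-2-yl on Two Related Cores

The source may hold more compounds than are shown below. What is called first, only, known or untested is meant among the compounds shown, and "the series" means these compounds.

Compound 1, `COc1ncnc2c1c(-c1cccs1)cn2[C@@H]1O[C@H](CO)[C@@H](O)[C@H]1O`: in a functional assay on CEM-DNR-bulk cells (Homo sapiens), read by MTT assay, with a stated time of 72 h (on this read-out lower numbers stand for stronger inhibition and higher numbers for weaker inhibition), compound 1 gives 12100 nM.
Compound 2, `COc1ncnc2c1c(-c1ccccc1)cn2[C@@H]1O[C@H](CO)[C@@H](O)[C@H]1O`: in this assay compound 2 gives > 20000 nM, which is a limit of the assay and not a number.
Compound 3, `CNc1ncnc2c1c(-c1ccccc1)cn2[C@@H]1O[C@H](CO)[C@@H](O)[C@H]1O`: in this assay compound 3 gives > 20000 nM, again a limit of the assay rather than a number.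

Among the measured compounds shown here, two of the three values sit at the limit of > 20000 nM in this assay, at which 2 of the 3 values shown sit, so only one pair can be read. Compound 1 differs from compound 2 by thiophen-2-yl in place of phenyl on an aromatic carbon, and that change gave an at least 1.6-fold lower number from compound 2 to compound 1 (0.21 log units; that floor lies within the scatter). The two cores differ by methylamino in place of methoxy on an aromatic carbon; the step between them is a step that the two limits leave unreadable from compound 2 to compound 3.

Compound 4, `CNc1ncnc2c1c(-c1cccs1)cn2[C@@H]1O[C@H](CO)[C@@H](O)[C@H]1O`, has not yet been measured in this assay. It differs from compound 3 by thiophen-2-yl in place of phenyl on an aromatic carbon. The place of this change is the same word for word as the place of the change from compound 2 to compound 1, so it is the same change made on the core of compound 3.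

The step expected from compound 3 to compound 4 is an at least 1.3-fold lower number from compound 3 to compound 4 (0.12 log units; that floor lies within the scatter). For the measured compounds named here, that expectation rests on an at least 1.6-fold lower number from compound 2 to compound 1 (0.21 log units; that floor lies within the scatter), the only measured instance of the same change. Compound 3 itself gives only a limit, > 20000 nM. For compound 4 the estimated value in this assay is 15000 nM, with a range from 6000 nM to 40000 nM, and a fair chance that the assay again reports only a limit.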

Compound 4, half-maximal inhibitory concentration: > 20000 nM
Compound 4 ended at the assay's limit (the forecaster's own chance of this, stated with the estimate: 45%); middle value at least 1.3-fold (0.12 log units) away from the limit.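

In this assay compound 4 gives > 20000 nM, which is a limit of the assay and not a number. The step of thiophen-2-yl in place of phenyl on the core of compound 3 therefore cannot be read, and neither can the other steps that join two limits, so the data show neither that the change carries over from the core of compound 2 nor that it fails to: the limit of > 20000 nM in this assay, at which 3 of the 4 values shown sit.

Among the compounds shown here, the one new step that can be read keeps thiophen-2-yl fixed and puts methylamino in place of methoxy, giving an at least 1.6-fold higher number from compound 1 to compound 4 (0.21 log units; that floor lies within the scatter), and since that floor lies within the scatter, it does not establish a real difference between the two cores, although the true gap could be larger.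

The compounds shown leave open whether any methylamino compound would give a number rather than a limit in this assay, for instance with a furyl group or a carboxylic acid on the aromatic carbon that bears phenyl or thiophen-2-yl. Also open, going by these compounds, is whether a dimethylamino group in place of methylamino would alter the picture on either the phenyl or the thiophen-2-yl compounds.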